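This account rests on a few compounds, and the source may have more. Where it says the series, first, only, none or still open, it means among the compounds named here.

Measured so far:
Compound 1 `O[C@H](c1ccccn1)[C@]1(c2cccc(OC(F)(F)F)c2)C[C@@H](O)C1`: 117 mL/min/kg
Compound 2 `OC(c1cc(F)ccn1)C1(c2ccc(Cl)c(Cl)c2)CCC1`: 533 mL/min/kg
Compound 3 `O[C@H](c1ccccn1)[C@]1(c2cccc(C(F)(F)F)c2)C[C@H](O)C1`: 133 mL/min/kg

All three numbers come from an ADME assay on liver for metabolic stability, with Liver microsome (Homo sapiens) as the target, read by LC-MS, using microsomes, with a stated time of 5 h; on this read-out higher numbers stand for fast clearance and lower numbers for slow clearance. Compound 1 and compound 3 lie within the usual scatter of each other, so these two cannot be told apart here. Compound 2 stands apart from compound 1, with a higher number beyond the scatter.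

Compound 4 `O[C@H](c1ccccn1)C1(c2cccc(OC(F)(F)F)c2)CCC1` has not yet been measured. It keeps the core of compound 1 and makes one change: hydrogen in place of hydroxy on a saturated ring carbon. In words, hydrogen takes the place of hydroxy on a saturated ring carbon.

For the measured compounds named here, no measured pair isolates this change, so the evidence is indirect. Compound 1 and compound 3 both carry a hydroxy on the four-membered ring, while compound 2 has none there and gives 533 mL/min/kg. Compound 2 also differs from compound 1 in its other groups, which makes it only a loose guide.

Even so, a rise in clearance beyond the scatter is expected, though probably not all the way to the number of compound 2. The estimated size of this rise is a 2.4-fold higher number from compound 1 to compound 4 (0.38 log units; beyond the scatter). The expected clearance of compound 4 is 280 mL/min/kg, with an estimated range of 140 mL/min/kg to 560 mL/min/kg.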

Compound 4, clearance: 2220 mL/min/kg
For compound 4 the middle estimate is 7.9-fold (0.90 log units) below the measured one; measured number above the stated range.
By their numbers in this assay, from the lowest: compounds 1 and 3 (each within the scatter of the next); then compound 2; then compound 4.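

For the compounds shown here, this pair gives the first direct reading of one saturated ring carbon of the four-membered ring, the one two ring bonds from the ring atom that bears the hydroxy(pyridin-2-yl)methyl group. In this assay, putting hydrogen in place of hydroxy at this carbon gives a 19-fold higher number from compound 1 to compound 4 (1.28 log units; beyond the scatter), a large step well beyond the scatter. The earlier compounds contained no pair differing in this one place alone, whereas here the two structures differ by a single oxygen atom, so this position is highly sensitive to the change, although no measurement here explains the size of the step.

From the compounds shown here alone, what remains open is whether the hydroxy is special or whether other groups on this ring carbon, such as a fluorine, a methoxy or an amine, would also keep the clearance close to that of compound 1. This is also a single pair built on the core of compound 1, so the compounds shown cannot say whether the same swap would give a step of similar size with a different group on the rest of the molecule.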